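The source may hold more compounds than are shown below. What is called first, only, known or untested is meant among the compounds shown, and "the series" means these compounds.

Measured compounds:

Compound 1 `NC(=O)c1c(NC(=O)c2cccc([N+](=O)[O-])c2)sc2c1CCN(Cc1ccc(Cl)cc1Cl)C2` — in a functional assay on HL-60 cells (Homo sapiens) for antiproliferative activity, with a stated time of 24 h (a higher number here means a weaker inhibitor, a lower number a stronger inhibitor), compound 1 gives 19800 nM.
Compound 2 `NC(=O)c1c(NC(=O)c2ccccc2F)sc2c1CCN(C(=S)Nc1ccccc1Cl)C2` — in this assay compound 2 gives 12500 nM.
Compound 3 `CSc1ccccc1C(=O)Nc1sc2c(c1C(N)=O)CCN(C(=S)Nc1ccccc1Cl)C2` — in this assay compound 3 gives 30500 nM.

Compound 3 sits at the upper end of these three numbers. Against compound 1 the gap is within the usual scatter, so the two cannot be told apart; against compound 2 the gap is beyond the scatter, as the single measured step shows: a 2.4-fold higher number from compound 2 to compound 3 (0.39 log units; beyond the scatter).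

Compound 4 `NC(=O)c1c(NC(=O)c2cccc([N+](=O)[O-])c2)sc2c1CCN(C(=S)Nc1ccccc1Cl)C2` is the next step. Its change from compound 3 is 3-nitrophenyl in place of 2-(methylsulfanyl)phenyl on a carbonyl carbon. Within the data shown here, no measured step covers this exact swap. Among the measured compounds shown here, the one step that exists, from compound 2 to compound 3, touches the same aromatic ring but exchanges a different group, and it was modest. Compound 1 carries the same 3-nitrophenyl as compound 4 but a different substituent on the ring nitrogen, so it is only a loose guide; compound 1 and compound 3 lie within the scatter of each other. On that basis the step from compound 3 to compound 4 is expected to be small or none beyond the scatter, a 1.8-fold lower number from compound 3 to compound 4 (0.25 log units; within the scatter). Compound 4 is therefore estimated at 17000 nM, with a likely range from 7000 nM to 40000 nM.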

Compound 4, half-maximal inhibitory concentration: 7040 nM
Compound 4: the middle estimate sits 2.4-fold (0.38 log units) above what was measured; low and high end bracket the measured number.
By their numbers in this assay, from the lowest: compounds 4, 2, 1 and 3 (each within the scatter of the next, the first and the last beyond it).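

In this assay, there is a 4.3-fold lower number from compound 3 to compound 4 (0.64 log units; beyond the scatter), which makes this the second step beyond the scatter at the carbonyl carbon and confirms that the aromatic group held there affects the number. The picture is not a simple ladder, though: there is a 1.8-fold lower number from compound 2 to compound 4 (0.25 log units; within the scatter), so 3-nitrophenyl and 2-fluorophenyl cannot be told apart here, and among these three groups only the 2-(methylsulfanyl)phenyl of compound 3 stands apart from the other two. Among these compounds, the result also gives the first reading at a second place in the molecule: with 3-nitrophenyl kept on the carbonyl carbon and the group on the amine nitrogen in a ring exchanged, there is a 2.8-fold lower number from compound 1 to compound 4 (0.45 log units; beyond the scatter), so that nitrogen's substituent matters as well.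

As far as these compounds go, it remains open how an aromatic ring carrying an amine or a carboxylic acid in place of the nitro group would behave on the carbonyl carbon, and whether the order of these aromatic groups would hold with another group on the ring nitrogen. Nothing available here explains any of these steps.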